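A few compounds are considered here, and "the series" means these few. Any claim that something is new, unique, unknown or untested is made for them only; others in the source may bear on it.

Measured so far:
compound 1, `CC(C)(C)OC(=O)N1CCC[C@H]1C(=O)N1CCC(NS(=O)(=O)c2cc(S(=O)(=O)c3ccccc3)ccc2C(F)(F)F)CC1`, with 60 nM;
compound 2, `CC(C)(C)OC(=O)N1CCC[C@@H]1C(=O)N1CCC(NS(=O)(=O)c2cc(S(=O)(=O)c3ccccc3)ccc2C(F)(F)F)CC1`, with 120 nM;
compound 3, `CN(C)c1ccc(C(=O)N2CCC[C@H]2C(=O)N2CCC(NS(=O)(=O)c3cc(S(=O)(=O)c4ccccc4)ccc3C(F)(F)F)CC2)cc1`, with 110 nM.

In an assay on isolated protein for binding affinity to secreted frizzled-related protein 1 (Homo sapiens), read by fluorescence (on this read-out lower numbers stand for stronger inhibition and higher numbers for weaker inhibition), compound 3 stands second highest of the three numbers; its nearest neighbour is compound 2 and its furthest compound 1, both within the scatter. Compound 4, `CN1CCC[C@H]1C(=O)N1CCC(NS(=O)(=O)c2cc(S(=O)(=O)c3ccccc3)ccc2C(F)(F)F)CC1`, differs from compound 3 by methyl in place of (4-(dimethylamino)phenyl)carbonyl on an amine nitrogen in a ring. Among the measured compounds shown here, two measured steps bear on this change: a 2.0-fold higher number from compound 1 to compound 2 (0.30 log units; within the scatter), small due to the fact that compounds 1 and 2 differ only in the configuration as drawn, and a 1.8-fold higher number from compound 1 to compound 3 (0.26 log units; within the scatter), which altered the group on the same carbonyl carbon that now leaves. Neither step moved beyond the scatter, so for compound 4 in this assay the expected step is estimated as a 1.4-fold higher number from compound 3 to compound 4 (0.13 log units; within the scatter), no larger than the scatter in either direction. The estimate for compound 4 is 150 nM, with a range from 50 nM to 450 nM.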

Compound 4, half-maximal inhibitory concentration: 120 nM
Estimate against measurement, compound 4: 1.3-fold (0.10 log units) above, and the stated range covers the measured number.
By their numbers in this assay, from the lowest: compounds 1, 3, 2 and 4 (each within the scatter of the next).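

In this assay, the group on the amine nitrogen in the ring shrinks to methyl with every step staying within the scatter: a 1.1-fold higher number from compound 3 to compound 4 (0.04 log units; within the scatter), a 2.0-fold higher number from compound 1 to compound 4 (0.30 log units; within the scatter), and no change at the digits printed from compound 2 to compound 4 (within the scatter). This position therefore keeps its numbers in the same range even without the carbonyl and the six-membered aromatic ring of the groups that leave. Nothing measured here accounts for this flat result.

From the compounds shown here alone, what remains open is whether a free amine, an ethyl group or a longer chain bearing a carboxylic acid on this nitrogen would give a step beyond the scatter.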